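Arylpiperazine swap on a hydantoin scaffold at the serotonin 7 receptor

A few compounds are considered here, and "the series" means these few. Any claim that something is new, unique, unknown or untested is made for them only; others in the source may bear on it.

Measured compounds:
compound 1 `CC1(c2ccc(F)cc2)NC(=O)N(CC(O)CN2CCN(c3ccccc3Cl)CC2)C1=O`: 47 nM
compound 2 `CC1(c2ccc(F)cc2)NC(=O)N(CC(O)CN2CCN(c3ccc(Cl)cc3)CC2)C1=O`: 908 nM

In an assay on HEK293 cells for displacement of a labelled ligand from 5-hydroxytryptamine receptor 7 (Homo sapiens) (a lower number here means a stronger inhibitor, a higher number a weaker inhibitor), compound 2 gives the higher of the two numbers shown; its nearest neighbour is compound 1, and the step of a 19-fold higher number from compound 1 to compound 2 (1.29 log units; beyond the scatter) is large. Compound 3 `Cc1ccc(N2CCN(CC(O)CN3C(=O)NC(C)(c4ccc(F)cc4)C3=O)CC2)cc1C` differs from compound 2 by 3,4-dimethylphenyl in place of 4-chlorophenyl on an amine nitrogen in a ring. Within the data shown here, no measured step tests this kind of exchange: the only step available moves a chlorine around the ring rather than replacing it with methyl groups, so it gives little guidance on direction. Compound 3 is therefore expected to stay close to compound 2, with the estimated step of a 1.5-fold lower number from compound 2 to compound 3 (0.18 log units; within the scatter), giving 600 nM within the range 150 nM to 2500 nM.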

Compound 3, inhibition constant: 177 nM
Compound 3: middle estimate off by 3.4-fold (0.53 log units), on the high side, within the range that was stated.
By their numbers in this assay, from the lowest: compound 1; then compound 3; then compound 2.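

Replacing the chlorine-bearing ring on the ring amine nitrogen with 3,4-dimethylphenyl gives a 5.1-fold lower number from compound 2 to compound 3 (0.71 log units; beyond the scatter) in this assay and so recovers part of the loss seen with 4-chlorophenyl. The recovery is incomplete, with a 3.8-fold higher number from compound 1 to compound 3 (0.58 log units; beyond the scatter) showing that 2-chlorophenyl remains the better of the three groups at this position. Nothing available explains either step.

From the compounds shown here alone, it remains open whether a single methyl group or a methoxy group on the phenyl ring would match 2-chlorophenyl. A pyridine ring in place of the phenyl ring is also untested in the compounds shown here.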